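The source may report more compounds than this note shows. Statements on the series, on what has been measured and on what is new or still open speak of the compounds shown alone.

Going by the values given here, in an in vitro ADME assay on microsomes from liver (Homo sapiens) for pharmacokinetics, read by LC-MS (on this read-out lower numbers stand for slow clearance and higher numbers for fast clearance), compound 1 `Cc1cccc2c1nc(C)n2-c1ccc(C(=O)NC2CC2)s1` gives 10 mL/min/kg and compound 2 `Cc1ccc2c(c1)nc(C)n2-c1ccc(C(=O)NC2CC2)s1` gives 8 mL/min/kg, so compound 2 stands within the scatter of the only other measured number. Compound 3 `Cc1nc2cc(OC(F)(F)F)ccc2n1-c1ccc(C(=O)NC2CC2)s1` has trifluoromethoxy in place of methyl on an aromatic carbon of compound 2, as counted here: trifluoromethoxy in place of methyl on an aromatic carbon. Among the compounds with values here, no measured pair of compounds differs in one place, so the data offer no precedent for this change. In this assay, no step beyond the scatter is expected, and the estimated step is a 1.3-fold higher number from compound 2 to compound 3 (0.10 log units; within the scatter). For compound 3, the expected clearance is 10 mL/min/kg, with an estimated range from 5 mL/min/kg to 20 mL/min/kg.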

Compound 3, clearance: 7 mL/min/kg
Estimate against measurement, compound 3: 1.4-fold (0.15 log units) above, within the range that was stated.
By their numbers in this assay, from the lowest: compounds 3, 2 and 1 (each within the scatter of the next).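

In this assay, going by these compounds alone, trifluoromethoxy in place of methyl on an aromatic carbon gives a 1.1-fold lower number from compound 2 to compound 3 (0.06 log units; within the scatter) and so offers the only single-place comparison in this set. It shows that this carbon, para to a fused ring, can carry trifluoromethoxy, with its hydrogen-bond acceptor, and that clearance stays within the scatter of the methyl compound. Nothing shown explains why clearance holds at this position. The compounds leave open whether an amine or a carboxylic acid on this carbon would also stay within the scatter.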